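Trifluoroacetyl replacing hydrogen on the aniline ring

The compounds below may be only part of what the source reports. "The series", "measured", "known", "first", "only" and "open" are said of these compounds alone.

Compound 2 `CN(C)CC[C@H](CSc1ccccc1)Nc1ccc(S(=O)(=O)NC(=O)c2ccc(N3CCN(Cc4ccccc4-c4ccc(Cl)cc4)CC3)cc2)cc1` is the anchor of the set: in an assay on isolated protein for displacement of a labelled ligand from Bcl2-associated agonist of cell death (Homo sapiens), read by fluorescence polarization (on this read-out higher numbers stand for weaker inhibition and lower numbers for stronger inhibition), compound 2 gives 14 nM, the only plain number shown. Compound 1 `CN(C)CC[C@H](CSc1ccccc1)Nc1ccc(S(=O)(=O)NC(=O)c2ccc(N3CCN(Cc4ccccc4-c4ccc(Cl)cc4)CC3)cc2)cc1C(F)(F)F` sits at a limit of the assay, < 1 nM. Compound 3 `CN(C)CC[C@H](CSc1ccccc1)Nc1ccc(S(=O)(=O)NC(=O)c2ccc(N3CCN(CC4=C(c5ccc(Cl)cc5)CCOC4)CC3)cc2)cc1[N+](=O)[O-]` likewise sits at a limit of the assay, < 1 nM. Compound 4 `CN(C)CC[C@H](CSc1ccccc1)Nc1ccc(S(=O)(=O)NC(=O)c2ccc(N3CCN(Cc4ccccc4-c4ccc(Cl)cc4)CC3)cc2)cc1C(=O)C(F)(F)F` carries a (trifluoromethyl)carbonyl in place of hydrogen on an aromatic carbon. Among the measured compounds shown here, the one measured step that bears on this position is an at least 14-fold higher number from compound 1 to compound 2 (1.14 log units; beyond the scatter), whose full size stays hidden because of the limit of < 1 nM in this assay, at which 2 of the 3 values shown sit. Compound 4 is expected to move in the reverse direction, a large fall in this assay, to about 1.5 nM (range 0.3 nM to 6 nM). The expected step is a 9.3-fold lower number from compound 2 to compound 4 (0.97 log units; beyond the scatter), with a fair chance that only a limit is returned.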

Compound 4, inhibition constant: < 1 nM
Compound 4 was reported as a limit (the forecaster's own chance of this, stated with the estimate: 45%); at least 1.5-fold (0.17 log units) between middle value and limit.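

In this assay, (trifluoromethyl)carbonyl in place of hydrogen on the aromatic carbon gives an at least 14-fold lower number from compound 2 to compound 4 (1.14 log units; beyond the scatter), so the fall in the number at this position is no longer tied to trifluoromethyl alone. The value of compound 4 is a limit, not a number. The step between compound 1 and compound 4 cannot be read, and no order of the two groups can be given, because both values are limits: the limit of < 1 nM in this assay, at which 3 of the 4 values shown sit.

Open, from the compounds shown here alone, is whether an amine, a carboxylic acid or a plain methyl at this position would also lower the number. Also open, going by these compounds, is how far trifluoromethyl and (trifluoromethyl)carbonyl differ.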